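Methoxy for Chloro on the Aryl Amide of Compound 1

This account rests on a few compounds, and the source may have more. Where it says the series, first, only, none or still open, it means among the compounds named here.

In a functional assay on A549 cells (Homo sapiens) for antiproliferative activity, read by MTT assay, with a stated time of 72 h (on this read-out lower numbers stand for stronger inhibition and higher numbers for weaker inhibition), compound 1 `O=C1COc2ccc(-c3cccc(NS(=O)(=O)c4ccc(F)cc4)c3)cc2N1c1ccc(Cl)cc1` gives 31600 nM, the highest of the two numbers in hand. Compound 2 `COc1ncc(-c2ccc3c(c2)N(C(C)C)C(=O)CO3)cc1NS(=O)(=O)c1ccc(F)cc1` gives 4920 nM in this assay, a gap beyond the scatter. Compound 3 `COc1ccc(N2C(=O)COc3ccc(-c4cccc(NS(=O)(=O)c5ccc(F)cc5)c4)cc32)cc1` differs from compound 1 by methoxy in place of chloro on an aromatic carbon. Among the compounds with values here, no measured pair shows this change, so the direction of the step is open, and no step beyond the scatter is expected. Compound 3 is therefore expected to give 22000 nM in this assay, with a range from 7000 nM to 60000 nM. The estimated step of a 1.4-fold lower number from compound 1 to compound 3 (0.16 log units; within the scatter) is expected to stay within the usual scatter.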

Compound 3, half-maximal inhibitory concentration: 38200 nM
Compound 3: middle estimate off by 1.7-fold (0.24 log units), on the low side, and the stated range covers the measured number.
By their numbers in this assay, from the lowest: compound 2; then compounds 1 and 3 (each within the scatter of the next).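

In this assay, within the data shown here, the change from 4-chlorophenyl to 4-methoxyphenyl gives a 1.2-fold higher number from compound 1 to compound 3 (0.08 log units; within the scatter), the first direct reading of a swap at this position. At this aromatic carbon, para to a large group, methoxy and chloro therefore cannot be told apart, and both compounds remain in the weak range of the numbers in hand. Nothing shown here bears on the reason for this result.

From the compounds shown here alone, whether an amine or a carboxylic acid on this carbon would move the number beyond the scatter stays open. So does whether a longer alkoxy chain would behave as methoxy does.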